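Trifluoromethoxy to chloro in a series held at a limit

This account rests on a few compounds, and the source may have more. Where it says the series, first, only, none or still open, it means among the compounds named here.

Compound 1 (`CCOC(=O)c1c(-c2cccc(OCC)c2)[nH]c2cc(OC)ccc2c1=O`) gives > 21500 nM in an ADME assay on Raji cells (Homo sapiens) for cytotoxicity, read by luminescence, with a stated time of 72 h (a higher number here means that more compound is needed for the effect, a lower number that less compound is needed), as a limit of the assay and not a number. Compound 2 (`CCCCOc1cccc(-c2[nH]c3cc(OC)ccc3c(=O)c2C(=O)OCC)c1`) gives > 21500 nM in the same way, again only a limit. Compound 3 (`CCOC(=O)c1c(-c2cccc(OC(F)(F)F)c2)[nH]c2cc(OC)ccc2c1=O`) gives > 21500 nM as well, so it too stands at a limit, and both further values beside it are limits. The whole set is summed up as the limit of > 21500 nM in this assay, at which 3 of the 3 values shown sit, and no measured number exists yet.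

Compound 4 (`CCOC(=O)c1c(-c2cccc(Cl)c2)[nH]c2cc(OC)ccc2c1=O`) keeps the shared core but carries chloro in place of trifluoromethoxy on an aromatic carbon, meta to a large group (chloro in place of trifluoromethoxy on an aromatic carbon) and is the next compound to be read.

Within the data shown here, three measured steps bear on this change, all of them exchanges of the group on the oxygen. They are a step that the two limits leave unreadable from compound 1 to compound 2 and a step that the two limits leave unreadable from compound 1 to compound 3 and a step that the two limits leave unreadable from compound 2 to compound 3 and none of them has a readable size. They offer no sign of a shift, so no change beyond the scatter is expected in this assay in either direction. The expected result is a number no higher from compound 3 to compound 4 (the limit leaves the size open) as an estimate.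

Compound 4 is expected at 21500 nM with an estimated range from 9000 nM to 43000 nM and a report of only a limit is the likeliest outcome.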

Compound 4, half-maximal effective concentration: > 21500 nM
Compound 4 was reported as a limit (the forecaster's own chance of this, stated with the estimate: 85%); the middle value sits exactly at the limit.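

Compound 1, compound 2, compound 3 and compound 4 all stand at a limit of the assay and not at a number in this assay, so no step among them can be read: the limit of > 21500 nM in this assay, at which 4 of the 4 values shown sit.

The compounds shown leave open whether ethoxy, butoxy, trifluoromethoxy or chloro changes the half-maximal effective concentration in this assay at all, and by how much.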